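Working notes: from compound 1 to compound 3

This account rests on a few compounds, and the source may have more. Where it says the series, first, only, none or still open, it means among the compounds named here.

Measured in a functional assay on SW-620 cells (Homo sapiens) for antiproliferative activity, read by MTT assay, with a stated time of 24 h (a higher number here means a weaker inhibitor, a lower number a stronger inhibitor), so far:
- compound 1 `COc1cccc(/C=C/C(=O)c2ccc(OC)c3c2OC(C)(C)C=C3)c1` gives > 10000 nM (a limit)
- compound 2 `COc1cc(OC)c(OC)cc1/C=C/C(=O)c1ccc(OC)c2c1OC(C)(C)C=C2` gives > 10000 nM (a limit)

Compound 1 stands at the limit of > 10000 nM in this assay, at which 2 of the 2 values shown sit, and so has a limit of the assay rather than a number. Among the measured compounds shown here, no step between measured compounds is available for sizing a change.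

Compound 3 `COc1ccc(C(=O)/C=C/c2cccc(F)c2)c2c1C=CC(C)(C)O2` keeps the core of compound 1 and has fluoro in place of methoxy on an aromatic carbon, meta to a large group (fluoro in place of methoxy on an aromatic carbon), which reads as 3-methoxyphenyl to 3-fluorophenyl.

With compound 1 and compound 2 both at the limit of > 10000 nM in this assay, at which 2 of the 2 values shown sit, no change beyond the scatter is expected in this assay and no direction is favoured. The expected step is a step that the limit leaves unreadable from compound 1 to compound 3 on this reading. For compound 3 the estimated value is 12000 nM (expected range 6000 nM to 25000 nM), and a report as a limit is the likeliest outcome.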

Compound 3, half-maximal inhibitory concentration: > 10000 nM
Compound 3: a limit, no number; the forecaster's own chance of this, stated with the estimate: 75%; the middle value does not contradict the limit.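

No step can be read from compound 1 to compound 3, because both values are limits and not numbers: the limit of > 10000 nM in this assay, at which 3 of the 3 values shown sit.

The compounds shown leave open how fluoro in place of methoxy changes the activity, and which change on the shared core, if any, gives a number instead of a limit.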